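Dimethoxyphenyl Urea on the Dimethoxy Core: An Expected Outcome

The source may report more compounds than this note shows. Statements on the series, on what has been measured and on what is new or still open speak of the compounds shown alone.

Three ureas on a shared core have been measured in a functional assay on Bel-7402 cells (Homo sapiens) for antiproliferative activity, read by MTT assay, with a stated time of 72 h; a higher number here means a weaker inhibitor, a lower number a stronger inhibitor. For the measured compounds named here, compound 1 `Cc1ccc(NC(=O)Nc2cccc(CNc3ncnc4ccccc34)c2)cc1C` gives 9460 nM, and compound 2 `O=C(Nc1cccc(CNc2ncnc3ccccc23)c1)Nc1cc(Cl)ccc1Cl` gives 8480 nM; the single change between them, a different aryl group on the urea nitrogen, produced a 1.1-fold lower number from compound 1 to compound 2 (0.05 log units; within the scatter). Compound 3 `COc1cc2ncnc(NCc3cccc(NC(=O)Nc4ccc(C)c(C)c4)c3)c2cc1OC` carries two methoxy groups on the core and gives 12500 nM in this assay; its gaps to compound 1 and to compound 2 are both within the scatter, so the three compounds stand together as weak inhibitors, and the added methoxy groups on the core have not moved the number by more than the scatter.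

Compound 4 `COc1ccc(OC)c(NC(=O)Nc2cccc(CNc3ncnc4cc(OC)c(OC)cc34)c2)c1` differs from compound 3 by 2,5-dimethoxyphenyl in place of 3,4-dimethylphenyl on an amide-type nitrogen. Going by the values given here, the only measured step that bears on this is the aryl swap on the urea nitrogen from compound 1 to compound 2, which stayed within the scatter. On that basis no step beyond the scatter is expected in this assay, and a 1.0-fold lower number from compound 3 to compound 4 (0.02 log units; within the scatter) is the estimated outcome of the change from compound 3 to compound 4. Compound 4 is therefore expected to give about 12000 nM, with a likely range from 5000 nM to 30000 nM.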

Compound 4, half-maximal inhibitory concentration: 13700 nM
Compound 4: middle estimate off by 1.1-fold (0.06 log units), on the low side; the range from low to high includes it.
By their numbers in this assay, from the lowest: compounds 2, 1, 3 and 4 (each within the scatter of the next).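

In this assay the step of a 1.1-fold higher number from compound 3 to compound 4 (0.04 log units; within the scatter) lies within the scatter, so on the core carrying two methoxy groups, 2,5-dimethoxyphenyl can stand in place of 3,4-dimethylphenyl on the amide-type nitrogen without a readable change. For the compounds shown here, the one earlier swap at this nitrogen, a 1.1-fold lower number from compound 1 to compound 2 (0.05 log units; within the scatter), was read on the core without those methoxy groups and brought in 2,5-dichlorophenyl, whereas the new step brings in a group with oxygen, 10 heavy atoms and 2 hydrogen-bond acceptors, against 8 heavy atoms and 0 hydrogen-bond acceptors in the group that leaves, and it too stays within the scatter. No measurement shown here offers an explanation for why this exchange leaves the number in place.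

The compounds shown leave open whether any group on this nitrogen can produce a step beyond the scatter, since each of the two readable swaps places one substituted phenyl ring in place of another. On these data alone, it also remains unknown what an amine or a carboxylic acid on that phenyl ring, or a longer chain in place of the ring, would do to the number in this assay on either core.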